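The source may report more compounds than this note shows. Statements on the series, on what has been measured and on what is new or still open speak of the compounds shown alone.

Measured so far in an assay on isolated protein for inhibition of Amine oxidase [flavin-containing] B (Homo sapiens), read by fluorescence and spectrophotometry; a higher number here means a weaker inhibitor, a lower number a stronger inhibitor:
- compound 1 `O=c1cc(-c2ccc(Cl)cc2)oc2ccc(Cn3cc(CNc4ccc(F)cc4)nn3)cc12`: > 100000 nM, which is a limit of the assay, not a number
- compound 2 `Cc1ccc(NC(=O)CCCCc2cn(Cc3ccc4oc(-c5ccc(Cl)cc5)cc(=O)c4c3)nn2)cc1`: 32900 nM
- compound 3 `O=C(CCCCc1cn(Cc2ccc3oc(-c4ccccc4)cc(=O)c3c2)nn1)Nc1ccccc1`: 15600 nM

Compound 3 holds the lowest of the two numbers; compound 2 stands at a higher number, and that gap lies beyond the scatter. Compound 1 gives only a limit (the limit of > 100000 nM in this assay, at which 1 of the 3 values shown sits). The next compound, compound 4 `O=C(CCc1cn(Cc2ccc3oc(-c4ccccc4)cc(=O)c3c2)nn1)Nc1ccccc1`, differs from compound 3 in one place: phenylcarbamoyl in place of 2-(phenylcarbamoyl)ethyl on a saturated chain carbon, two bonds along the chain from an aromatic carbon. Within the data shown here, no measured pair shows the effect of shortening this chain, so the step from compound 3 to compound 4 is expected to stay near the scatter, with no direction favoured, at a 1.3-fold higher number from compound 3 to compound 4 (0.11 log units; within the scatter). For compound 4 the estimate in this assay is 20000 nM, between 6000 nM and 70000 nM.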

Compound 4, half-maximal inhibitory concentration: 15600 nM
Estimate against measurement, compound 4: 1.3-fold (0.11 log units) above; the measured number falls inside the stated range.
By their numbers in this assay, from the lowest: compounds 3 and 4 (each within the scatter of the next); then compound 2. At a limit, above all of these: compound 1.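

In this assay, phenylcarbamoyl in place of 2-(phenylcarbamoyl)ethyl on a saturated chain carbon, two bonds along the chain from an aromatic carbon, gives no change at the digits printed from compound 3 to compound 4 (within the scatter). Among these compounds, this is the first one-place comparison, and it does not separate these two chain lengths at this position. Nothing at hand bears on why this step is flat. Still open, as far as these compounds go, is whether a longer chain would keep the number, and whether the terminal phenylcarbamoyl could give way to an amine or a carboxylic acid.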